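Solubility notes: one aryl swap, tested twice on a shared core

The source may hold more compounds than are shown below. What is called first, only, known or untested is meant among the compounds shown, and "the series" means these compounds.

Compound 2 `COc1ccc(F)cc1CNCCCNc1ccnc2cc(-c3cccc4ccccc34)ccc12` and compound 1 `COc1ccc(F)cc1CNCCCNc1ccnc2cc(Oc3ccc(Cl)cc3)ccc12` differ in one place, (4-chlorophenoxy in place of naphthalen-1-yl on an aromatic carbon). In a physicochemical assay for solubility, with a stated time of 18 h, at pH 7.4 (a higher number here means a more soluble compound, a lower number a less soluble compound), compound 2 gives 32000 nM, and compound 1 gives 14500 nM; the step between them is a 2.2-fold lower number from compound 2 to compound 1 (0.34 log units; beyond the scatter).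

Compound 3 `COc1cccc(CNCCCNc2ccnc3cc(-c4cccc5ccccc45)ccc23)c1O` differs from compound 2 at another place, (2-hydroxy-3-methoxyphenyl in place of 5-fluoro-2-methoxyphenyl on a saturated chain carbon bound to an amine nitrogen). In this assay compound 3 gives 32000 nM, and the step is no change at the digits printed from compound 2 to compound 3 (within the scatter), so compound 2 and compound 3 stand level at the digits given, and compound 1 sits apart from both.

Compound 4 `COc1cccc(CNCCCNc2ccnc3cc(Oc4ccc(Cl)cc4)ccc23)c1O` has not yet been measured. It differs from compound 3 by 4-chlorophenoxy in place of naphthalen-1-yl on an aromatic carbon. Among the measured compounds shown here, this is the same change as the one from compound 2 to compound 1, made at the same place; it occurs twice among the four compounds, and its one measured instance reads a 2.2-fold lower number from compound 2 to compound 1 (0.34 log units; beyond the scatter). On the core that carries 2-hydroxy-3-methoxyphenyl rather than 5-fluoro-2-methoxyphenyl, a step of similar size is expected, a 2.2-fold lower number from compound 3 to compound 4 (0.34 log units; beyond the scatter), because compound 3 starts from 32000 nM and the only measured case of this change gave a 2.2-fold lower number from compound 2 to compound 1 (0.34 log units; beyond the scatter). The expectation rests on a single pair, so its spread must stay wide.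

Compound 4 is therefore expected to give about 14500 nM in this assay, with a likely range from 7000 nM to 30000 nM.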

Compound 4, solubility: 14500 nM
Estimate against measurement, compound 4: no gap at the digits printed; measured number inside the range.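

In this assay, 4-chlorophenoxy in place of naphthalen-1-yl on the core carrying 2-hydroxy-3-methoxyphenyl gives a 2.2-fold lower number from compound 3 to compound 4 (0.34 log units; beyond the scatter), which matches a 2.2-fold lower number from compound 2 to compound 1 (0.34 log units; beyond the scatter) on the core carrying 5-fluoro-2-methoxyphenyl, so the change carries over at the same size in these two pairs. The other change in this set, 2-hydroxy-3-methoxyphenyl in place of 5-fluoro-2-methoxyphenyl, agrees with that reading: it gives no change at the digits printed from compound 1 to compound 4 (within the scatter) with 4-chlorophenoxy on the core and no change at the digits printed from compound 2 to compound 3 (within the scatter) with naphthalen-1-yl. Among the compounds shown here, this covers only two cores that differ in one group, so it sets no rule for other cores, and nothing measured here bears on why the numbers sit where they do.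

The compounds shown leave open whether the same step appears on a core with a morpholine or a carboxylic acid in place of the 2-hydroxy-3-methoxyphenyl group, or with a longer chain in place of the present saturated chain. They also leave open how a plain phenoxy group would read in this assay, so the step cannot be divided between the oxygen and the chlorine of 4-chlorophenoxy.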